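The source may report more compounds than this note shows. Statements on the series, on what has been measured and on what is new or still open speak of the compounds shown alone.

Of the compounds shown here, two built on the same core have been tested in an assay on cells for inhibition of Voltage-dependent T-type calcium channel subunit alpha-1H (Homo sapiens), read by FLIPR and calcium flux, with stated times of 600 s and 300 s; on this read-out lower numbers stand for stronger inhibition and higher numbers for weaker inhibition. Compound 1, `CN(C)CCCOc1ccc(CN(C)c2nc3ccc(Oc4ccc(C(F)(F)F)cc4)cc3s2)cc1`, gives 54000 nM. Compound 2, `CN(Cc1ccc(OCCCN)cc1)c1nc2ccc(Oc3ccc(O)cc3)cc2s1`, gives 165000 nM, the higher of the two numbers, and its gap to compound 1 lies beyond the usual scatter of the measurement. Compound 3, `CN(Cc1ccc(OCCCN)cc1)c1nc2ccc(Oc3ccc(C(F)(F)F)cc3)cc2s1`, has not yet been measured. It differs from compound 2 in one place: trifluoromethyl in place of hydroxy on an aromatic carbon. The same trifluoromethyl group is already present in compound 1, which gives the lower number of the two, so a step toward a lower number is expected, not a change within the scatter. Compound 3 is therefore expected to come in near compound 1, with an estimated step of a 3.3-fold lower number from compound 2 to compound 3 (0.52 log units; beyond the scatter). The estimate for compound 3 in this assay is 50000 nM, expected to fall between 20000 nM and 120000 nM.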

Compound 3, half-maximal inhibitory concentration: 248000 nM
For compound 3 the middle estimate is 5.0-fold (0.70 log units) below the measured one; measured number outside the range, above it.
By their numbers in this assay, from the lowest: compound 1; then compounds 2 and 3 (each within the scatter of the next).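

In this assay, putting trifluoromethyl in place of hydroxy on this aromatic carbon gives a 1.5-fold higher number from compound 2 to compound 3 (0.18 log units; within the scatter) and so, with the amino chain in place, this swap produces no change that can be told from the scatter. The trifluoromethyl group alone is therefore not enough to bring the number to the level of compound 1. Within the data shown here, with trifluoromethyl kept, amino in place of dimethylamino on the saturated chain carbon gives a 4.6-fold higher number from compound 1 to compound 3 (0.66 log units; beyond the scatter) and this is the one step here that clearly stands out from the scatter, though it is modest and rests on a single pair.

Open, on these data alone, is how hydroxy reads alongside the dimethylamino chain, and how a methoxy group or chlorine on this aromatic carbon, or a methylamino group in place of the amino group, would read. Nothing measured here gives a reason for either step.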